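The compounds below may be only part of what the source reports. "The series", "measured", "known", "first", "only" and "open" are said of these compounds alone.

The measured compounds:
compound 1 `N[C@@H](CSNC(=O)[C@@H](CCC(F)(F)F)N(Cc1ccc(-c2ncon2)cc1F)S(=O)(=O)c1ccc(Cl)cc1)C(=O)O`: in a physicochemical assay for solubility, at pH 2 (on this read-out lower numbers stand for lower solubility and higher numbers for higher solubility), compound 1 gives 510 ug/mL.
compound 2 `N#CCCSNC(=O)[C@@H](CCC(F)(F)F)N(Cc1ccc(-c2ncon2)cc1F)S(=O)(=O)c1ccc(Cl)cc1`: in this assay compound 2 gives < 1 ug/mL, which is a limit of the assay.

Compound 1 holds the only number shown; the other value is a limit. Compound 3 `CCOC(=O)[C@@H](N)CSNC(=O)[C@@H](CCC(F)(F)F)N(Cc1ccc(-c2ncon2)cc1F)S(=O)(=O)c1ccc(Cl)cc1` differs from compound 1 by ethyl in place of hydrogen on an oxygen next to a carbonyl group, that is, carboxy to ethoxycarbonyl. Going by the values given here, the single measured step, an at least 510-fold lower number from compound 1 to compound 2 (2.70 log units; beyond the scatter), removed the whole amino(carboxy)methyl group. That step ended at the limit of < 1 ug/mL in this assay, at which 1 of the 2 values shown sits. Because an at least 510-fold lower number from compound 1 to compound 2 (2.70 log units; beyond the scatter) went with loss of both the amino and the acid groups, while compound 3 keeps the amino group, a smaller downward step is expected for compound 3, a 10-fold lower number from compound 1 to compound 3 (1.01 log units; beyond the scatter). For compound 3 the estimate in this assay is 50 ug/mL, from 5 ug/mL to 300 ug/mL.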

Compound 3, solubility: 4300 ug/mL
Compound 3: the middle estimate sits 86-fold (1.93 log units) below what was measured, outside the stated range (above it).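

In this assay, ethoxycarbonyl does not lower the number at this position: the change from carboxy gives an 8.4-fold higher number from compound 1 to compound 3 (0.93 log units; beyond the scatter), so a free carboxy group is not needed for a high value here. Set against cyanomethyl, amino(ethoxycarbonyl)methyl gives an at least 4300-fold higher number from compound 2 to compound 3 (3.63 log units; beyond the scatter). Compound 2 stands at a limit of the assay: the limit of < 1 ug/mL in this assay, at which 1 of the 3 values shown sits. The compounds shown leave open whether the amine alone goes with this gap, and how a chain bearing the amine without any ester, a methyl ester or a primary amide would read in this assay.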